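The source may report more compounds than this note shows. Statements on the series, on what has been measured and on what is new or still open speak of the compounds shown alone.

Of the compounds shown here, three sharing one core have been measured so far. In a functional assay on RS4-11 cells (Homo sapiens) for inhibition, read by CCK-8 assay, with a stated time of 48 h, tested at 20 uM (a higher number here means more inhibition of growth at the concentration tested, a lower number less inhibition of growth), compound 1 `COc1ccc(Cc2nnc(NC(=O)/C(C#N)=C/c3ccccc3OS(=O)(=O)c3ccc(C)cc3)s2)cc1` gives 70% while compound 2 `COc1ccc(Cc2nnc(NC(=O)/C(C#N)=C/c3ccccc3OS(=O)(=O)c3ccc(OC)cc3)s2)cc1` gives 78% and compound 3 `COc1ccc(Cc2nnc(NC(=O)/C(C#N)=C/c3ccccc3OS(=O)(=O)c3ccc([N+](=O)[O-])cc3)s2)cc1` gives 70% in the same test. Compound 3 thus stands level with compound 1, and all three numbers lie within the scatter of one another.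

The next compound, compound 4 `N#C/C(=C\c1ccccc1OS(=O)(=O)c1ccc([N+](=O)[O-])cc1)C(=O)Nc1nnc(Cc2ccc(Cl)cc2)s1`, differs from compound 3 in one group: chloro in place of methoxy on an aromatic carbon, para to a large group, which turns 4-methoxybenzyl into 4-chlorobenzyl chloro in place of methoxy on an aromatic carbon and leaves the rest unchanged.

The measured steps are a number 8 percentage points higher from compound 1 to compound 2 (within the scatter) for methoxy in place of methyl, no change at the digits printed from compound 1 to compound 3 (within the scatter) for nitro in place of methyl and a number 8 percentage points lower from compound 2 to compound 3 (within the scatter) for nitro in place of methoxy on an aromatic carbon. All three change a different part of the molecule, and all three compounds carry the 4-methoxybenzyl group, so no measurement speaks directly to this swap. They show only small movement elsewhere on the shared core. The expected step is no change at the digits printed from compound 3 to compound 4 (within the scatter) by estimate, with none anticipated beyond the scatter and no direction favoured. In this assay the estimate for compound 4 is 70% with 55% to 85% as the expected range.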

Compound 4, percent growth inhibition at one concentration: 66%
Beside the measured number, compound 4's estimate is 4 percentage points above it; measured number inside the range.
By their numbers in this assay, from the lowest: compounds 4, 1, 3 and 2 (each within the scatter of the next, the first and the last beyond it).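

In this assay, the swap of 4-methoxybenzyl for 4-chlorobenzyl gives a number 4 percentage points lower from compound 3 to compound 4 (within the scatter), so on this ring, para to a large group, chloro can stand in place of methoxy without a shift beyond the scatter. The earlier steps shown here all altered the other aromatic ring while the 4-methoxybenzyl group stayed fixed, so they said nothing about this end of the molecule; this pair shows that the methoxy, with its two heavy atoms and one hydrogen-bond acceptor, can give way to a single chlorine atom with no acceptor and the reading stays within the scatter. No supporting measurement bears on why the reading holds here.

For the compounds shown here, the swap is seen only with the nitro group on the other ring, so it remains open whether chloro would read the same with the methyl or methoxy found there in the other compounds. On these data alone, it also remains open how an amine, a carboxylic acid or a longer chain at this same place would read, and whether any group here can move growth inhibition beyond the scatter.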